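A few compounds are considered here, and "the series" means these few. Any claim that something is new, unique, unknown or untested is made for them only; others in the source may bear on it.

Measured so far:
- compound 1, `Cc1cc2occ(-c3nc(-c4ccccc4)c(-c4ccccc4)n3-c3ccccc3Cl)c(=O)c2cc1Cl`: "not determined" (no result reported) in an ADME assay on MCF-10A cells (Homo sapiens) for cytotoxicity, read by MTT assay, with a stated time of 72 h; a lower number here means a stronger inhibitor, a higher number a weaker inhibitor
- compound 2, `Cc1cc2occ(-c3nc(-c4ccccc4)c(-c4ccccc4)n3-c3ccc(Cl)c(Cl)c3)c(=O)c2cc1Cl`: 98000 nM
- compound 3, `Cc1ccc(-n2c(-c3coc4cc(C)c(Cl)cc4c3=O)nc(-c3ccccc3)c2-c2ccccc2)cc1`: "not determined" (no result reported)

The three measured compounds share one core and differ only in the aryl group carried on the imidazole nitrogen. Of them only compound 2 returned a number in this assay, and that number shows it to be a weak inhibitor. Compound 3 stands without a single number in this assay, and compound 1 is a further entry that likewise has no number, so compound 3 cannot be placed against either neighbour on the values shown.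

The step of interest leads from compound 3 to compound 4, `Cc1cc2occ(-c3nc(-c4ccccc4)c(-c4ccccc4)n3-c3ccc([N+](=O)[O-])cc3)c(=O)c2cc1Cl`, which is to be measured in this assay. The change is nitro in place of methyl on an aromatic carbon. Among the measured compounds shown here, no pair of measured compounds with a step between them is available, so the size of this step cannot be read from a precedent. For the measured compounds named here, the only anchor is compound 2, whose value in this assay is weak, and compound 4 is expected to sit in the same weak region, with any step from compound 3 not resolvable beyond the scatter. Compound 4 is therefore estimated at 80000 nM, with a range from 30000 nM to 200000 nM.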

Compound 4, half-maximal inhibitory concentration: > 100000 nM
Compound 4: no number, only a limit (the forecaster's own chance of this, stated with the estimate: 30%); middle value at least 1.2-fold (0.09 log units) from the limit.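

In this assay compound 4 gives > 100000 nM, which is a limit of the assay and not a number. With 4-nitrophenyl in place of 3,4-dichlorophenyl on the imidazole nitrogen, the result is an at least 1.0-fold higher number from compound 2 to compound 4 (0.00 log units; that floor lies within the scatter), so these two aryl groups are not told apart in this assay. This gives the position a second compound with a reported result, and neither result marks a strong inhibitor, with compound 4 the one entry at the limit: the limit of > 100000 nM in this assay, at which 1 of the 4 values shown sits.

The step from 4-methylphenyl to 4-nitrophenyl cannot be read: compound 3 has no number, and compound 1 has none either, so the methyl to nitro change itself remains without a size. Also open, from the compounds shown here alone, is whether an aryl group carrying an amine or a carboxylic acid on this ring would give a lower number in this assay, or whether every group at this position stays in the same region.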